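The source may hold more compounds than are shown below. What is called first, only, known or untested is meant among the compounds shown, and "the series" means these compounds.

Compound 3, `Cc1ncc([N+](=O)[O-])n1CC(O)Cn1cc(C(=O)O)c(=O)c2cc(F)ccc21`, gives -0.13 in a physicochemical assay for lipophilicity, using the shake flask method, measured as octanol-water partition; on this read-out lower numbers stand for lower lipophilicity and higher numbers for higher lipophilicity. Its number sits close to those of the other two measured compounds: compound 1, `Cc1ncc([N+](=O)[O-])n1CC(O)Cn1cc(C(=O)O)c(=O)c2cc(F)cc(F)c21`, gives -0.21, and compound 2, `Cc1ccc2c(c1)c(=O)c(C(=O)O)cn2CC(O)Cn1c([N+](=O)[O-])cnc1C`, gives -0.03, and both gaps to compound 3 are within the scatter, so the three numbers cannot be told apart with confidence.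

Compound 4, `COc1ccc2c(c1)c(=O)c(C(=O)O)cn2CC(O)Cn1c([N+](=O)[O-])cnc1C`, has not been measured in this assay. It differs from compound 3 in one place: methoxy in place of fluoro on an aromatic carbon.

Going by the values given here, two measured steps touch the same aromatic carbon and so bear on this change. The step of a number 0.08 log units higher from compound 1 to compound 3 (within the scatter), in which hydrogen replaces fluoro, and the step of a number 0.10 log units lower from compound 2 to compound 3 (within the scatter), in which fluoro replaces methyl, both stayed within the scatter. Among the compounds with values here, neither step put a methoxy group in place, so the present change has no direct precedent here, but both show that swapping a small group at this carbon moved this assay little. The expected step of a number 0.17 log units lower from compound 3 to compound 4 (within the scatter) is therefore small, and if anything slightly downward, though it may well not rise beyond the scatter. For compound 4 the estimate in this assay is -0.3, with a range from -0.7 to 0.1.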

Compound 4, partition coefficient: -0.24
Compound 4: middle estimate off by 0.06 log units, on the low side; the range from low to high includes it.
By their numbers in this assay, from the lowest: compounds 4, 1, 3 and 2 (each within the scatter of the next).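

In this assay, the change of fluoro to methoxy on this aromatic carbon is a number 0.11 log units lower from compound 3 to compound 4 (within the scatter) and the change of methyl to methoxy is a number 0.21 log units lower from compound 2 to compound 4 (within the scatter) so neither new step can be told apart from no change at all. Compounds 2, 3 and 4 therefore show that this carbon tolerated a group that differs from fluoro in its count, with methoxy bringing 2 heavy atoms and 1 hydrogen-bond acceptor where fluoro has 1 heavy atom and 0 hydrogen-bond acceptors, without a step that rises beyond the scatter in this read-out. Nothing measured alongside these numbers offers an explanation for how little they differ.

As far as these compounds go, what stays open is whether this flat picture is special to small groups, as fluoro, methyl and methoxy are all compact, or whether it would hold for an amine or a longer chain such as butoxy on the same carbon. A group of that kind on this carbon of the shared core would show whether a step beyond the scatter can be reached here at all, or whether this position stays as quiet as it has so far.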